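Swapping the Anilino Aryl for a Pyridinylmethyl Group

This account rests on a few compounds, and the source may have more. Where it says the series, first, only, none or still open, it means among the compounds named here.

Compound 3 `COc1cc(/C=C/c2nc(Nc3ccc(O)cc3)c3sccc3n2)cc(OC)c1OC` sits at the weak end of the three measured compounds. In a functional assay on L02 cells (Homo sapiens) for inhibition, read by Griess assay, with stated times of 1 h and 24 h (a lower number here means a stronger inhibitor, a higher number a weaker inhibitor), compound 3 gives > 1000000 nM, which is a limit of the assay and not a number. Compound 1 `COc1cc(/C=C/c2nc(N(C)C)c3sccc3n2)cc(OC)c1OC` likewise reaches only a limit, > 1000000 nM. Compound 2 `COc1cc(/C=C/c2nc(Nc3ccc(C)cc3)c3sccc3n2)cc(OC)c1OC` gives < 40000 nM, again a limit. The change to compound 4 `COc1cc(/C=C/c2nc(NCc3ccncc3)c3sccc3n2)cc(OC)c1OC` is (pyridin-4-yl)methyl in place of 4-hydroxyphenyl on a nitrogen on an aromatic ring. Within the data shown here, two measured steps bear on it: an at least 25-fold higher number from compound 2 to compound 3 (1.39 log units; beyond the scatter) and an at least 25-fold lower number from compound 1 to compound 2 (1.39 log units; beyond the scatter), both large, while a step that the two limits leave unreadable from compound 1 to compound 3. Since compound 3 stands at the limit of > 1000000 nM in this assay, at which 2 of the 3 values shown sit, and the hydroxy of an at least 25-fold higher number from compound 2 to compound 3 (1.39 log units; beyond the scatter) leaves, a downward step in this assay is expected, estimated as an at least 3.3-fold lower number from compound 3 to compound 4 (0.52 log units; beyond the scatter), though its size is uncertain. Compound 4 is therefore estimated at 300000 nM, within a range from 30000 nM to 3000000 nM.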

Compound 4, half-maximal inhibitory concentration: 374000 nM
Beside the measured number, compound 4's estimate is 1.2-fold (0.10 log units) below it, within the range that was stated.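

Among these compounds, compound 4 is the first compound in this assay to give a number and not a limit. With (pyridin-4-yl)methyl on the nitrogen, the data show an at least 2.6-fold lower number from compound 3 to compound 4 (0.42 log units; beyond the scatter) and an at least 2.6-fold lower number from compound 1 to compound 4 (0.42 log units; beyond the scatter) but also an at least 9.3-fold higher number from compound 2 to compound 4 (0.97 log units; beyond the scatter) in the same comparison set, so this position separates all three replacements. Nothing measured here gives a cause for these steps.

The compounds shown leave open whether the ring nitrogen or the added carbon link accounts for this. A benzyl group on the same nitrogen would separate the two.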